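Amide-side variation and tolerated concentration in the series

The source may hold more compounds than are shown below. What is called first, only, known or untested is meant among the compounds shown, and "the series" means these compounds.

Of the compounds shown here, three have been measured in an ADME assay on CEM-SS cells (Homo sapiens) for cytotoxicity, read by XTT assay, with a stated time of 6 days; a higher number here means that more compound is tolerated, a lower number that less compound is tolerated. Compound 1 `CCCC(=O)OCSc1ccc(OC)cc1C(=O)NCCC(N)=O` gives > 100 uM, which is a limit of the assay rather than a number, and sits at the limit of > 100 uM in this assay, at which 1 of the 3 values shown sits. Compound 2 `CCCC(=O)OCSc1ccccc1C(=O)NCCCCCCNC(C)=O` gives 8 uM in this assay, and compound 3 `CCCC(=O)OCSc1ccccc1C(=O)N[C@@H]1CCC[C@@H]1C(N)=O` gives 90 uM. Compound 3 thus holds the higher of the two numbers, the value of compound 2 lying lower by a gap beyond the scatter. Compound 4 `C#CCNC(=O)CNC(=O)c1ccccc1SCOC(=O)CCC` remains to be measured in this assay. It differs from compound 3 by (propargylcarbamoyl)methyl in place of 2-carbamoylcyclopentyl on an amide-type nitrogen. Among the measured compounds shown here, no step between measured compounds that differ in one place is available to guide the size. Compound 3 stands close to the limit. The step of a 1.3-fold lower number from compound 3 to compound 4 (0.11 log units; within the scatter) is expected to be small, not beyond the scatter. Compound 4 is estimated at 70 uM, between 20 uM and 100 uM.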

Compound 4, half-maximal toxic concentration: 95.4 uM
Compound 4: middle estimate off by 1.4-fold (0.13 log units), on the low side; low and high end bracket the measured number.
By their numbers in this assay, from the lowest: compound 2; then compounds 3 and 4 (each within the scatter of the next). At a limit, above all of these: compound 1.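

Here the 2-carbamoylcyclopentyl ring with its 2 defined stereocentres gives way to the open (propargylcarbamoyl)methyl, and this assay does not separate the two compounds (a 1.1-fold higher number from compound 3 to compound 4 (0.03 log units; within the scatter)). The step beyond the scatter comes instead where propargylcarbamoyl replaces 5-acetamidopentyl (a 12-fold higher number from compound 2 to compound 4 (1.08 log units; beyond the scatter)), so the low number stays with compound 2 alone. Compound 1 remains a limit of the assay, not a number: (the limit of > 100 uM in this assay, at which 1 of the 4 values shown sits).

Open, as far as these compounds go, is whether an amine or a carboxylic acid on the amide-type nitrogen side would keep the tolerated concentration this high. From the compounds shown here alone, a longer chain ending in a primary amide is equally open.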